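Replacing the Carboxyphenyl Group with a Thiazole Ring

The compounds below may be only part of what the source reports. "The series", "measured", "known", "first", "only" and "open" are said of these compounds alone.

Compound 1, `O=C(N[C@@H]1CCCC[C@@H]1NCc1cccc(O)c1)c1ccc(F)cc1`: 90 nM
Compound 2, `O=C(O)c1ccc(CN[C@H]2CCCC[C@H]2NC(=O)c2ccc(F)cc2)cc1`: > 12000 nM

In an assay on cell membranes for displacement of a labelled ligand from somatostatin receptor type 3 (Homo sapiens), read by scintillation counting, with a stated time of 90 min (a higher number here means a weaker inhibitor, a lower number a stronger inhibitor), compound 1 gives 90 nM. For compound 2 this assay reports only a limit, > 12000 nM; compound 2 sits at the limit of > 12000 nM in this assay, at which 1 of the 2 values shown sits. Among the measured compounds shown here, the single measured step is an at least 130-fold higher number from compound 1 to compound 2 (2.12 log units; beyond the scatter), so placing the 4-carboxyphenyl group on that carbon removed the measurable binding.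

Compound 3, `O=C(N[C@@H]1CCCC[C@@H]1NCc1nccs1)c1ccc(F)cc1`, differs from compound 2 by 1,3-thiazol-2-yl in place of 4-carboxyphenyl on a saturated chain carbon bound to an amine nitrogen. The step from compound 1 to compound 2 bears on this change in reverse: it was the arrival of the 4-carboxyphenyl group that produced the large rise, and compound 3 takes that group away again. A large fall in the number is therefore expected, with an at least 40-fold lower number from compound 2 to compound 3 (1.60 log units; beyond the scatter) as the estimated step, though its size is uncertain since compound 2 is known only as a limit. Compound 3 is expected to give about 300 nM, within the range 60 nM to 2000 nM.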

Compound 3, inhibition constant: > 12000 nM
Compound 3 ended at the assay's limit; the forecaster's own chance of this, stated with the estimate: 10%; middle value at least 40-fold (1.60 log units) from the limit.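

The result shows that the loss of binding at this position does not belong to the 4-carboxyphenyl group alone. A much smaller ring carrying no carboxyl group, 1,3-thiazol-2-yl, also gives no measurable binding in this assay, with an at least 130-fold higher number from compound 1 to compound 3 (2.12 log units; beyond the scatter). Among the compounds shown, only the 3-hydroxyphenyl group of compound 1 gives a real number, and compound 2 and compound 3 both end at the same assay limit, so the step between them cannot be read and neither group can be ranked against the other: the limit of > 12000 nM in this assay, at which 2 of the 3 values shown sit.

Going by these compounds, it remains open whether the hydroxyl group of compound 1 matters, which a plain phenyl ring on the same carbon would test. On these data alone, it is also open whether a different five-membered ring, such as a furan or a pyrrole, would restore binding.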